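The compounds below may be only part of what the source reports. "The series", "measured", "known", "first", "only" and "open" are said of these compounds alone.

Measured so far:
compound 1, `CCC(C)C(N)c1cc(C(F)(F)F)ccc1N1CCN(C(=O)CCc2ccc(Cl)cc2Cl)CC1`: 160 nM in an assay on HEK293 cells for displacement of a labelled ligand from Melanocortin receptor 4 (Homo sapiens); a lower number here means a stronger inhibitor, a higher number a weaker inhibitor
compound 2, `CCC(C)[C@H](N)c1cc(C(F)(F)F)ccc1N1CCN(C(=O)CCc2ccc(OC)cc2Cl)CC1`: 57 nM in this assay

Of the two numbers, compound 1 stands at the higher, weaker end; compound 2 is at the lower end, a gap beyond the scatter. Going by the values given here, no single-point step between measured compounds is available, and compound 2 differs from compound 1 in two places, so nothing fixes the effect of either change alone.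

Compound 3, `CC(C)C[C@H](NC(=O)CCN)c1cc(C(F)(F)F)ccc1N1CCN(C(=O)CCc2ccc(Cl)cc2Cl)CC1`, has not been measured. It differs from compound 1 in one place: 1-(((2-aminoethyl)carbonyl)amino)-3-methylbutyl in place of 1-amino-2-methylbutyl on an aromatic carbon.

Among the compounds with values here, with no step to lean on, the expectation for compound 3 is a modest change, direction uncertain, so a 1.2-fold lower number from compound 1 to compound 3 (0.09 log units; within the scatter) is an estimate with a wide band. Compound 3 is expected near 130 nM, between 30 nM and 600 nM.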

Compound 3, inhibition constant: 25 nM
The estimate for compound 3 lay 5.2-fold (0.72 log units) above the measured number, outside the stated range (below it).
By their numbers in this assay, from the lowest: compound 3; then compound 2; then compound 1.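

The aromatic carbon meta to a trifluoromethyl group tolerates a larger substituent: in this assay, 1-(((2-aminoethyl)carbonyl)amino)-3-methylbutyl in place of 1-amino-2-methylbutyl gives a 6.4-fold lower number from compound 1 to compound 3 (0.81 log units; beyond the scatter) and so brings a gain beyond the scatter. This is the only step shown that can be read as a change in one place. Nothing on hand accounts for the gain.

This single step changes both the branched alkyl part and the amine, and the compounds shown do not separate the two. Open, going by these compounds, is how a free amine on the 3-methylbutyl chain, a longer aminoalkyl chain or a terminal carboxylic acid would compare.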